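Furan-2-yl in place of thiophen-2-yl on the shared core

The compounds below may be only part of what the source reports. "The series", "measured", "known", "first", "only" and "open" are said of these compounds alone.

In a functional assay on CEM-DNR cells (Homo sapiens), read by MTT assay, with a stated time of 3 days (on this read-out higher numbers stand for weaker inhibition and lower numbers for stronger inhibition), compound 1 `CN(C)c1ncnc2[nH]cc(Sc3cccs3)c12` gives 35300 nM, and compound 2 `c1csc(Sc2c[nH]c3ncnc(-c4cccs4)c23)c1` gives 17700 nM. Only these two numbers exist so far, and they lie within the usual scatter of each other, so neither compound can be called the better inhibitor. Compound 3 `c1coc(-c2ncnc3[nH]cc(Sc4cccs4)c23)c1` differs from compound 2 in one place: furan-2-yl in place of thiophen-2-yl on an aromatic carbon. In words, furan-2-yl stands in place of thiophen-2-yl on an aromatic carbon. Going by the values given here, the only measured step at this place is a 2.0-fold lower number from compound 1 to compound 2 (0.30 log units; within the scatter). That step exchanged dimethylamino for thiophen-2-yl and did not leave the scatter. The new exchange keeps a five-membered aromatic ring, so no change beyond the scatter is expected in this assay. The expected step is a 1.0-fold higher number from compound 2 to compound 3 (0.01 log units; within the scatter). For compound 3 the estimated value is 18000 nM, with an expected range of 7500 nM to 42000 nM.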

Compound 3, half-maximal inhibitory concentration: 20800 nM
Compound 3: middle estimate off by 1.2-fold (0.06 log units), on the low side; low and high end bracket the measured number.
By their numbers in this assay, from the lowest: compounds 2, 3 and 1 (each within the scatter of the next).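

In this assay, exchanging the thiophen-2-yl for furan-2-yl on this aromatic carbon gives a 1.2-fold higher number from compound 2 to compound 3 (0.07 log units; within the scatter), so replacing the ring sulfur with oxygen makes no measurable difference here. Furan-2-yl in place of dimethylamino gives a 1.7-fold lower number from compound 1 to compound 3 (0.23 log units; within the scatter), so compound 3, like compound 2, cannot be told apart from compound 1, and this holds for two different five-membered aromatic rings. No measured evidence here bears on why these groups read alike.

As far as these compounds go, whether a group of another kind on this carbon, such as a carboxylic acid or a phenyl ring, would produce a step beyond the scatter remains open. The other thiophene-bearing part of the molecule is the same in all three compounds, so its contribution is open too.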